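The source may hold more compounds than are shown below. What is called first, only, known or untested is meant among the compounds shown, and "the series" means these compounds.

Of the compounds shown here, three have so far been measured in an assay on isolated protein for inhibition of Amine oxidase [flavin-containing] B (Homo sapiens), read by Amplex Red, with a stated time of 15 min; a higher number here means a weaker inhibitor, a lower number a stronger inhibitor. Compound 1 `CC(=O)c1ccc(OCc2cccc([N+](=O)[O-])c2)cc1` gives 104 nM in this assay, and compound 2 `CC(=O)c1ccc(OCc2ccc([N+](=O)[O-])cc2)cc1` gives 96.5 nM. Compound 3 `CC(=O)c1cccc(OCc2cccc(F)c2)c1`, built on a different core from the other two, gives 193 nM in this assay. Its number is the highest of the three, yet the gaps to compound 1 and to compound 2 both fall within the usual scatter of repeated measurements, so no order among the three can be read from these numbers.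

Compound 4 `CC(=O)c1cccc(OCc2cccc([N+](=O)[O-])c2)c1` has not yet been measured. It shares the core of compound 3 and differs from it in one place: nitro in place of fluoro on an aromatic carbon. Among the measured compounds shown here, no measured pair shows this exchange on this core. For the measured compounds named here, the only nitro compounds measured are compound 1 and compound 2, whose values in this assay sit close to one another, but they carry the other core and so provide no step that transfers directly. The step from compound 3 to compound 4 is therefore expected to be small, a 1.3-fold lower number from compound 3 to compound 4 (0.11 log units; within the scatter), and may well not reach beyond the scatter. Compound 4 is accordingly estimated at 150 nM in this assay, with a range from 50 nM to 450 nM.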

Compound 4, half-maximal inhibitory concentration: 114 nM
Compound 4: the middle estimate sits 1.3-fold (0.12 log units) above what was measured; the measured number falls inside the stated range.
By their numbers in this assay, from the lowest: compounds 2, 1, 4 and 3 (each within the scatter of the next).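

Among the compounds shown here, the step of a 1.7-fold lower number from compound 3 to compound 4 (0.23 log units; within the scatter) in this assay is the first one that can be read on the core of compound 3, and the earlier compounds showed nitro only on the other core. At this position, on an aromatic carbon meta to a large group, a single fluorine can give way to nitro, with three heavy atoms and two hydrogen-bond acceptors, without any change that stands clear of the scatter. The position therefore accepts both groups within the limits of this comparison, and no measurement shown here bears on why the exchange behaves this way.

The compounds shown leave open whether another group at this position, such as an amine, a carboxylic acid or a methoxy group, would move the number beyond the scatter. For the compounds shown here, they also hold no fluoro compound on the core of compound 1, so whether the same exchange gives a similar step on that core remains an open question.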